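A few compounds are considered here, and "the series" means these few. Any claim that something is new, unique, unknown or untested is made for them only; others in the source may bear on it.

Measured so far in a functional assay on HeLa cells (Homo sapiens) for antiproliferative activity, read by MTT assay, with a stated time of 72 h; on this read-out higher numbers stand for weaker inhibition and lower numbers for stronger inhibition:
- compound 1 `O=c1c(CSC(=S)N2CCCC2)coc2cc(Cl)ccc12`: 1300 nM
- compound 2 `CC(C)N(C(=S)SCc1coc2ccccc2c1=O)C(C)C`: reported only as a limit, > 30000 nM
- compound 3 `CN1CCN(C(=S)SCc2coc3ccccc3c2=O)CC1`: 5900 nM

Compound 3 stands at the highest of the two numbers in this assay; the nearest is compound 1, whose number is lower, beyond the scatter. Compound 2 sits at the limit of this assay the limit of > 30000 nM in this assay, at which 1 of the 3 values shown sits, and gives no number.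

Within the data shown here, the one measured step, an at least 5.0-fold lower number from compound 2 to compound 3 (0.70 log units; beyond the scatter), shows that exchanging the amine on the thiocarbonyl carbon can move the number well beyond the scatter.

Compound 4 `O=c1c(CSC(=S)N2CCCC2)coc2ccccc12` differs from compound 3 by pyrrolidin-1-yl in place of 4-methylpiperazin-1-yl on a thiocarbonyl carbon. Among the measured compounds shown here, no measured step covers this exchange. Compound 1 carries the same pyrrolidin-1-yl, but its core also differs, so its value only shows that a pyrrolidin-1-yl compound can sit below compound 3.

Compound 4 is therefore expected to give a modest decrease, a 2.4-fold lower number from compound 3 to compound 4 (0.37 log units; beyond the scatter), with the estimate for compound 4 at 2500 nM, between 800 nM and 8000 nM.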

Compound 4, half-maximal inhibitory concentration: > 25000 nM
Compound 4 was reported as a limit; the forecaster's own chance of this, stated with the estimate: 5%; middle value at least 10-fold (1.00 log units) away from the limit.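

In this assay compound 4 is reported only as a limit, not a number: the limit of > 25000 nM in this assay, at which 1 of the 4 values shown sits.

On the thiocarbonyl carbon, with the core held the same, pyrrolidin-1-yl in place of 4-methylpiperazin-1-yl gives an at least 4.2-fold higher number from compound 3 to compound 4 (0.62 log units; beyond the scatter), so this amine exchange can also raise the number. With pyrrolidin-1-yl held the same, hydrogen in place of chloro on an aromatic carbon gives an at least 19-fold higher number from compound 1 to compound 4 (1.28 log units; beyond the scatter), which ties the lower number of compound 1 to the chloro in this pair.

The step from compound 2 to compound 4 joins two limits and cannot be read. Open, on these data alone, is whether chloro has the same effect alongside 4-methylpiperazin-1-yl, and where a morpholine or piperidine amine would fall.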